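The source may report more compounds than this note shows. Statements on the series, on what has been measured and on what is new or still open speak of the compounds shown alone.

In a functional assay on HL-60 cells (Homo sapiens) for inhibition, read by CCK-8 assay, with a stated time of 48 h (a lower number here means a stronger inhibitor, a higher number a weaker inhibitor), compound 1 (`Cc1ccc(S(=O)(=O)Oc2ccccc2/C=C(\C#N)C(=O)Nc2nnc(C)s2)cc1`) gives 11500 nM and compound 2 (`Cc1ccc(S(=O)(=O)Oc2cccc(/C=C(\C#N)C(=O)Nc3nnc(-c4cccs4)s3)c2)cc1`) gives 8750 nM while compound 3 (`COc1ccc(S(=O)(=O)Oc2ccccc2/C=C(\C#N)C(=O)Nc2nnc(Cc3cccc4ccccc34)s2)cc1`) gives 4700 nM as its number, which lies within the scatter of compound 2 and beyond the scatter below compound 1. Compound 4 (`COc1ccc(S(=O)(=O)Oc2ccccc2/C=C(\C#N)C(=O)Nc2nnc(Cc3ccc(C)cc3)s2)cc1`) differs from compound 3 by 4-methylphenyl in place of naphthalen-1-yl on a saturated chain carbon bound to an aromatic carbon. Among the compounds with values here, no measured pair shows such a change, so only a small rise in the number is expected in this assay, probably within the scatter. The expected step is a 1.4-fold higher number from compound 3 to compound 4 (0.14 log units; within the scatter) at the middle of the estimate. For compound 4 the estimate is 6500 nM with 3000 nM to 14000 nM as its expected range.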

Compound 4, half-maximal inhibitory concentration: 4080 nM
Estimate against measurement, compound 4: 1.6-fold (0.20 log units) above; measured number inside the range.
By their numbers in this assay, from the lowest: compounds 4, 3, 2 and 1 (each within the scatter of the next, the first and the last beyond it).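

In this assay, within the data shown here, 4-methylbenzyl in place of (naphthalen-1-yl)methyl gives a 1.2-fold lower number from compound 3 to compound 4 (0.06 log units; within the scatter), the first comparison here of compounds that differ in one place. At this place, on a saturated chain carbon bound to an aromatic carbon, one six-membered aromatic ring serves as well as two within the scatter, so the second ring is not needed to hold the number. No evidence at hand accounts for this result.

From the compounds shown here alone, whether this place would accept a non-aromatic group, such as an amine or a carboxylic acid, remains open. So does the effect of a longer chain between the core and the aromatic ring.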